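Chain extension from compound 2 to compound 4

The source may hold more compounds than are shown below. What is called first, only, known or untested is meant among the compounds shown, and "the series" means these compounds.

Of the compounds shown here, three have been read in a functional assay on HT-29 cells (Homo sapiens) for cytotoxicity, read by MTT assay, with a stated time of 48 h (a lower number here means a stronger inhibitor, a higher number a weaker inhibitor), and the read-out is the half-maximal inhibitory concentration. Compound 1 `COc1cc(/C=C/C2=CC(=O)CC(c3ccc(O)c(OC)c3)N2CCCO)ccc1O` gives > 100000 nM, which is a limit of the assay and not a number. Compound 3 `COCCNC(=C\C(=O)/C=C/c1ccc(O)c(OC)c1)/C=C/c1ccc(O)c(OC)c1` gives > 100000 nM, again a limit of the assay. Within the data shown here, compound 2 `COCCNC(=C\C(=O)/C=C/c1ccc(O)cc1)/C=C/c1ccc(O)cc1` gives 57400 nM, the only true number in the set, so it is the sole numerical anchor for what follows.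

The next compound is compound 4 `COCCCNC(=C\C(=O)/C=C/c1ccc(O)cc1)/C=C/c1ccc(O)cc1`. Its difference from compound 2 is methoxymethyl in place of methoxy on a saturated chain carbon, two bonds along the chain from an amine nitrogen. The same difference reads as (2-methoxyethyl)amino to (3-methoxypropyl)amino.

Among the measured compounds shown here, no pair of measured compounds differing in one place is available, so the size of this step has no direct precedent. With compound 2 at 57400 nM as the only reference, no change beyond the usual scatter is expected in this assay, and neither direction is favoured. The expected step of a 1.0-fold lower number from compound 2 to compound 4 (0.02 log units; within the scatter) is therefore small. A reading that returns only a limit remains possible. Compound 4 is estimated at 55000 nM, with an expected range of 25000 nM to 100000 nM.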

Compound 4, half-maximal inhibitory concentration: 51900 nM
The estimate for compound 4 lay 1.1-fold (0.03 log units) above the measured number; the range from low to high includes it.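

In this assay, among these compounds, a 1.1-fold lower number from compound 2 to compound 4 (0.04 log units; within the scatter) is the only step that can be read at this position. Methoxymethyl in place of methoxy on a saturated chain carbon, two bonds along the chain from an amine nitrogen, therefore gives readings that cannot be told apart, and the same holds for (2-methoxyethyl)amino and (3-methoxypropyl)amino in this series. The series now has a second true number on this side chain, yet the readable values still stand not far from the end of the scale, which limits how much can be drawn from a step of this size: the limit of > 100000 nM in this assay, at which 2 of the 4 values shown sit.

As far as these compounds go, whether a terminal amine, a carboxylic acid or a longer chain at this place would give a reading distinct from those of compound 2 and compound 4 remains open. Also open, from the compounds shown here alone, is whether the same chain change on the core of compound 3, which reads only as a limit of the assay, would give a true number.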